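The source may hold more compounds than are shown below. What is called first, only, known or untested is meant among the compounds shown, and "the series" means these compounds.

Measured in a functional assay on WI-38 VA13 cells (Homo sapiens) for cytotoxicity; on this read-out higher numbers stand for an effect only at larger amounts of compound and lower numbers for an effect already at smaller amounts:
compound 1 `O=C(Nc1ccc2nc(NC(=O)C3CCCCC3)sc2c1)c1ccccc1Cl` gives 0.025 ug/mL;
compound 2 `N#Cc1ccc(C(=O)Nc2ccc3nc(NC(=O)C4CCCCC4)sc3c2)cc1` gives 3.3 ug/mL;
compound 3 `O=C(Nc1ccc2nc(NC(=O)C3CCCCC3)sc2c1)c1cccnc1Cl` gives 0.075 ug/mL.

Compound 3 stands second highest of the three in this assay, close to the lowest number (a 3.0-fold higher number from compound 1 to compound 3 (0.48 log units; beyond the scatter)) and far from the highest (a 44-fold lower number from compound 2 to compound 3 (1.64 log units; beyond the scatter)). Compound 4 `Cc1cc(C(=O)Nc2ccc3nc(NC(=O)C4CCCCC4)sc3c2)n(C)n1` differs from compound 3 by 1,3-dimethyl-1H-pyrazol-5-yl in place of 2-chloropyridin-3-yl on a carbonyl carbon. Going by the values given here, no measured step exchanges this ring for a five-membered one. The bearing steps are the modest 3.0-fold higher number from compound 1 to compound 3 (0.48 log units; beyond the scatter), where one six-membered ring replaced another, and the large 130-fold higher number from compound 1 to compound 2 (2.12 log units; beyond the scatter), where the chlorine-bearing ring was lost. As the chlorine-bearing ring is lost here too, a rise beyond the scatter is expected, of size a 13-fold higher number from compound 3 to compound 4 (1.12 log units; beyond the scatter). Compound 4 is estimated at 1 ug/mL, within 0.15 ug/mL to 8 ug/mL.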

Compound 4, half-maximal effective concentration: 0.12 ug/mL
The estimate for compound 4 lay 8.3-fold (0.92 log units) above the measured number, outside the stated range (below it).
By their numbers in this assay, from the lowest: compound 1; then compounds 3 and 4 (each within the scatter of the next); then compound 2.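

In this assay the change reads a 1.6-fold higher number from compound 3 to compound 4 (0.20 log units; within the scatter) and so places a five-membered ring without chlorine, 1,3-dimethyl-1H-pyrazol-5-yl, level with 2-chloropyridin-3-yl on this carbonyl carbon. With a 28-fold lower number from compound 2 to compound 4 (1.44 log units; beyond the scatter) as the gap between two chlorine-free rings, a low number at this position does not need chlorine, and chlorine-free rings are not alike here. Still, a 4.8-fold higher number from compound 1 to compound 4 (0.68 log units; beyond the scatter) leaves compound 1 with the lowest number.

No evidence on hand explains these steps. As far as these compounds go, whether an amine or a carboxylic acid on the 1,3-dimethyl-1H-pyrazol-5-yl group, or a longer chain in place of its methyl groups, keeps the number low stays open.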